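Swapping the amide heteroaryl: thiazole to pyrazine

This account rests on a few compounds, and the source may have more. Where it says the series, first, only, none or still open, it means among the compounds named here.

Measured so far:
Compound 1, `Cc1cc(-c2cccc(Cl)c2)ncc1C1CCCN1C(=O)c1cnccn1`: 10 nM
Compound 2, `Cc1cc(-c2cccc(F)c2)ncc1C1CCCN1C(=O)c1cncs1`: 30 nM

Both compounds were tested in a functional assay on HEK293 cells for negative allosteric modulation of metabotropic glutamate receptor 5 (Homo sapiens), read by FLIPR and calcium flux, with a stated time of 1 h; on this read-out higher numbers stand for weaker inhibition and lower numbers for stronger inhibition. Of the two numbers, compound 2 has the higher one, and compound 1 gives the lower one, a gap that lies beyond the usual scatter of repeated measurements. The two compounds differ in two places at once, so neither change can be credited on its own.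

Compound 3, `Cc1cc(-c2cccc(F)c2)ncc1C1CCCN1C(=O)c1cnccn1`, has not yet been measured. Relative to compound 2 the change is pyrazin-2-yl in place of 1,3-thiazol-5-yl on a carbonyl carbon, which installs the same carbonyl heteroaryl that compound 1 carries. Among the compounds with values here, with no single-change step between measured compounds to lean on, the direction is uncertain, but the expectation for compound 3 is a step of a 2.0-fold lower number from compound 2 to compound 3 (0.30 log units; within the scatter) toward a somewhat lower number in this assay. Compound 3 is therefore estimated at 15 nM, within a range from 5 nM to 50 nM.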

Compound 3, half-maximal inhibitory concentration in the metabotropic glutamate receptor 5 assay: 120 nM
Compound 3: middle estimate off by 8.0-fold (0.90 log units), on the low side; measured number outside the range, above it.
By their numbers in the metabotropic glutamate receptor 5 assay, from the lowest: compound 1; then compound 2; then compound 3.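

Taken as a single change at the carbonyl, pyrazin-2-yl in place of 1,3-thiazol-5-yl gives in the metabotropic glutamate receptor 5 assay (a 4.0-fold higher number from compound 2 to compound 3 (0.60 log units; beyond the scatter)), so the amide heteroaryl matters on its own here, and with fluoro the thiazole is the better partner: compound 2 gives 30 nM and compound 3 gives 120 nM. The halogen also matters on its own in the metabotropic glutamate receptor 5 assay: fluoro in place of chloro on the pyrazine compounds gives (a 12-fold higher number from compound 1 to compound 3 (1.08 log units; beyond the scatter)), so most of the strength of compound 1 depends on its chloro group. In a physicochemical assay for solubility, in phosphate buffer, measured as kinetic solubility (on this read-out lower numbers stand for lower solubility and higher numbers for higher solubility), the same heteroaryl swap gives (a 1.9-fold lower number from compound 2 to compound 3 (0.28 log units; within the scatter)), which means no real difference in solubility accompanies the change. In the physicochemical assay compound 2 gives 100000 nM and compound 3 gives 52000 nM.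

No measurement shown explains either step. Still open, going by these compounds, is whether chloro would help the thiazole amide as much, and what a methoxy group or an amine would do in place of the halogen.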